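Adding a Methyl to the Amide Chain of Compound 1

The compounds below may be only part of what the source reports. "The series", "measured", "known", "first", "only" and "open" are said of these compounds alone.

Compound 1 `CCC(=O)Nc1ccc(S(=O)(=O)Oc2ccccc2C(C)C)cc1`: 2100 nM
Compound 2 `CCC(=O)Nc1ccc(S(=O)(=O)Oc2ccccc2I)cc1`: 7200 nM

In a functional assay on HT-1080 cells (Homo sapiens) for antiproliferative activity, read by sulforhodamine B assay, with a stated time of 48 h (on this read-out lower numbers stand for stronger inhibition and higher numbers for weaker inhibition), compound 1 gives 2100 nM, the lowest of the two numbers shown; the only measured step, a 3.4-fold higher number from compound 1 to compound 2 (0.54 log units; beyond the scatter), is modest and beyond the scatter. Compound 3 `CC(C)C(=O)Nc1ccc(S(=O)(=O)Oc2ccccc2C(C)C)cc1` has not yet been measured. It differs from compound 1 by methyl in place of hydrogen on a saturated chain carbon bound to a carbonyl carbon and a saturated chain carbon. That single known step concerns a different part of the structure, an exchange on the aromatic carbon, and so gives no guide to a change on the amide chain. With nothing to suggest otherwise, a step within the scatter is expected, a 1.2-fold higher number from compound 1 to compound 3 (0.08 log units; within the scatter). Compound 3 is therefore estimated at 2500 nM, with a range from 1000 nM to 6500 nM.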

Compound 3, half-maximal inhibitory concentration: 4900 nM
Estimate against measurement, compound 3: 2.0-fold (0.29 log units) below; measured number inside the range.
By their numbers in this assay, from the lowest: compound 1; then compounds 3 and 2 (each within the scatter of the next).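

In this assay the change from ethyl to isopropyl on the amide chain gives a 2.3-fold higher number from compound 1 to compound 3 (0.37 log units; beyond the scatter) and so shows that this position responds to one added methyl, with weaker inhibition as the result. Among the compounds shown here, this is the first change seen on the amide side of the core of compound 1. Nothing available explains the loss.

As far as these compounds go, whether a longer chain such as butanoyl, a ring such as cyclopropyl, or an amine on this chain would do better remains open. So does whether the added methyl has the same effect with iodo on the aromatic carbon.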